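Butyl in Place of Propyl: One Carbon Added

The compounds below may be only part of what the source reports. "The series", "measured", "known", "first", "only" and "open" are said of these compounds alone.

Three compounds have numbers so far in an ADME assay on LL24 cells (Homo sapiens) for inhibition, read by MTT assay, with a stated time of 24 h; a higher number here means a weaker inhibitor, a lower number a stronger inhibitor:

compound 1 `CCCCNc1ccc(C(=O)N/N=C/c2ccc([N+](=O)[O-])o2)cc1` gives 47000 nM
compound 2 `CCCc1ccc(C(=O)N/N=C/c2ccc([N+](=O)[O-])o2)cc1` gives 89000 nM
compound 3 `CC(C)(C)OC(=O)N/N=C/c1ccc([N+](=O)[O-])o1` gives > 200000 nM, which is a limit of the assay and not a number

Among the two numbers, compound 2 has the higher one; its nearest neighbour is compound 1, and the step of a 1.9-fold higher number from compound 1 to compound 2 (0.28 log units; within the scatter) is within the scatter, so no order between the two can be read. The limit for compound 3 is described by the limit of > 200000 nM in this assay, at which 1 of the 3 values shown sits.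

Compound 4 `CCCCc1ccc(C(=O)N/N=C/c2ccc([N+](=O)[O-])o2)cc1` is compound 2 with one change, (methyl in place of hydrogen on a saturated chain carbon, three bonds along the chain from an aromatic carbon).

Going by the values given here, only one measured step exists, from compound 1 to compound 2, and it exchanges the group on the aromatic carbon rather than lengthening a chain; it was a 1.9-fold higher number from compound 1 to compound 2 (0.28 log units; within the scatter), within the scatter. Among the compounds with values here, no measured step tests methyl in place of hydrogen on a saturated chain carbon, so the expectation rests on the general picture of small shifts seen here. The account therefore expects the step of a 1.0-fold lower number from compound 2 to compound 4 (0.02 log units; within the scatter) to stay within the scatter, in no particular direction. In this assay compound 4 is estimated at 85000 nM, expected between 35000 nM and 190000 nM.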

Compound 4, half-maximal inhibitory concentration: > 200000 nM
Compound 4: a limit, no number; the forecaster's own chance of this, stated with the estimate: 15%; middle value at least 2.3-fold (0.37 log units) away from the limit.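

In this assay compound 4 gives > 200000 nM, which is a limit of the assay and not a number, and such a reading is no longer a lone case: the limit of > 200000 nM in this assay, at which 2 of the 4 values shown sit.

Going by these compounds alone, at this position, three bonds along the chain from an aromatic carbon, methyl in place of hydrogen gives an at least 2.2-fold higher number from compound 2 to compound 4 (0.35 log units; beyond the scatter), so the first measured change on a saturated chain carbon shows that propyl to butyl, a single added carbon, is enough to move the reading beyond the scatter. Butyl in place of butylamino on the aromatic carbon gives an at least 4.2-fold higher number from compound 1 to compound 4 (0.62 log units; beyond the scatter), also beyond the scatter, whereas propyl in place of butylamino gave only a 1.9-fold higher number from compound 1 to compound 2 (0.28 log units; within the scatter), so the exchange of the butylamino group now has a readable outcome with the butyl group, though not with the propyl group.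

The compounds shown leave open how far compound 4 lies past its limit, and with it the full size of both new steps. They also leave open whether a pentyl chain, or a butyl chain ending in an amine, would give a number at all in this assay.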